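A few compounds are considered here, and "the series" means these few. Any claim that something is new, unique, unknown or untested is made for them only; others in the source may bear on it.

Three compounds sharing one core have been examined in an ADME assay on L02 cells (Homo sapiens) for cytotoxicity, read by MTT assay, with a stated time of 72 h; a higher number here means a weaker inhibitor, a lower number a stronger inhibitor. Compound 1 `COc1ccccc1NC(=O)CCC(=O)OCCCCCCSc1ccc([N+](=O)[O-])c2nonc12` gives 4490 nM, compound 2 `O=C(CCC(=O)OCCCCCCSc1ccc([N+](=O)[O-])c2nonc12)Nc1cccc(Cl)c1` gives 6930 nM, and compound 3 `O=C(CCC(=O)OCCCCCCSc1ccc([N+](=O)[O-])c2nonc12)Nc1ccc(Br)cc1` gives 4330 nM. The three stand close together: the shift is a 1.5-fold higher number from compound 1 to compound 2 (0.19 log units; within the scatter), a 1.0-fold lower number from compound 1 to compound 3 (0.02 log units; within the scatter) and a 1.6-fold lower number from compound 2 to compound 3 (0.20 log units; within the scatter), so compound 3 is separated from both of its companions by no more than the usual scatter, and no ordering among the three can be claimed.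

The next compound, compound 4 `O=C(CCC(=O)OCCCCCCSc1ccc([N+](=O)[O-])c2nonc12)NCCN1CCCC1`, is reached from compound 3 by the change (2-(pyrrolidin-1-yl)ethyl in place of 4-bromophenyl on an amide-type nitrogen). Among the measured compounds shown here, every measured step so far exchanges one substituted aromatic ring for another on the amide-type nitrogen, and each of those steps stayed within the scatter. None of them replaces the aromatic ring by a 2-(pyrrolidin-1-yl)ethyl group, so the measured steps give no direct guide to this change, only the observation that this position has so far tolerated variation without moving the number. On that basis a step of a 1.0-fold higher number from compound 3 to compound 4 (0.02 log units; within the scatter) in this assay is expected, that is, no movement beyond the scatter, though the range is kept wide. The value for compound 4 in this assay is estimated at 4500 nM, between 1200 nM and 17000 nM.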

Compound 4, half-maximal inhibitory concentration: 6580 nM
The estimate for compound 4 lay 1.5-fold (0.17 log units) below the measured number, within the range that was stated.
By their numbers in this assay, from the lowest: compounds 3, 1, 4 and 2 (each within the scatter of the next).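

In this assay, the amide-type nitrogen now carries a group with no aromatic ring, and 2-(pyrrolidin-1-yl)ethyl, with its five-membered non-aromatic ring and 1 hydrogen-bond acceptor, stays within the scatter of all three aromatic companions: the shift is a 1.5-fold higher number from compound 3 to compound 4 (0.18 log units; within the scatter) and a 1.5-fold higher number from compound 1 to compound 4 (0.17 log units; within the scatter) and also a 1.1-fold lower number from compound 2 to compound 4 (0.02 log units; within the scatter) in this series. Across these four compounds, then, the number does not depend on an aromatic ring at this position, a tolerance that the earlier steps could show only for one substituted aromatic ring exchanged for another. Nothing available here explains this flat response at the amide-type nitrogen.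

The compounds shown leave open whether this tolerance extends to an open-chain dimethylamino group in place of the pyrrolidine ring, to a morpholine ring, to a carboxylic acid, or to a longer chain in place of the ethyl link. They also leave open whether the number would hold if the six-carbon chain or the ester of the shared core were changed, since every step here lies at the amide-type nitrogen.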